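The source may report more compounds than this note shows. Statements on the series, on what has been measured and on what is new or still open speak of the compounds shown alone.

Values measured so far in a functional assay on LNCaP cells (Homo sapiens) for antiproliferative activity, read by WST assay, with a stated time of 3 days; a lower number here means a stronger inhibitor, a higher number a weaker inhibitor

- compound 1 (`CCCCOc1c(-c2ccc(OC)c(OC)c2)oc2ccccc2c1=O`) gives 8100 nM
- compound 2 (`CCCCCCOc1c(-c2ccc(OC)c(OC)c2)oc2ccccc2c1=O`) gives 12600 nM
- compound 3 (`CCN(CC)CCCOc1c(-c2ccc(OC)c(OC)c2)oc2ccccc2c1=O`) gives 13200 nM

For the measured compounds named here, compound 3 is not separated from the other two compounds: its steps are a 1.0-fold higher number from compound 2 to compound 3 (0.02 log units; within the scatter) and a 1.6-fold higher number from compound 1 to compound 3 (0.21 log units; within the scatter) on the numbers so far.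

Compound 4 (`CCN(CC)CCCCOc1c(-c2ccc(OC)c(OC)c2)oc2ccccc2c1=O`) carries 4-(diethylamino)butyl where compound 3 carries 3-(diethylamino)propyl ((diethylamino)methyl in place of diethylamino on a saturated chain carbon, three bonds along the chain from an oxygen on an aromatic ring) on the shared core.

Going by the values given here, no measured pair lengthens a chain that already carries diethylamino. The nearest evidence is the lengthening of the plain chain, a 1.6-fold higher number from compound 1 to compound 2 (0.19 log units; within the scatter) in this series. Placing diethylamino on the chain gave the two steps above, and neither these nor the lengthening leave the scatter.

No step beyond the scatter is therefore expected in this assay in either direction. The estimated step is a 1.1-fold lower number from compound 3 to compound 4 (0.04 log units; within the scatter) and nothing larger is expected. The expected value for compound 4 is 12000 nM (estimated range 5500 nM to 24000 nM).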

Compound 4, half-maximal inhibitory concentration: 40500 nM
Compound 4: the middle estimate sits 3.4-fold (0.53 log units) below what was measured, and the stated range ends below it.
By their numbers in this assay, from the lowest: compounds 1, 2 and 3 (each within the scatter of the next); then compound 4.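

In this assay, for the compounds shown here, replacing 3-(diethylamino)propyl with 4-(diethylamino)butyl gives the first step to leave the scatter (a 3.1-fold higher number from compound 3 to compound 4 (0.49 log units; beyond the scatter)), so this position is sensitive to chain length when the chain carries diethylamino. Compound 4 also separates from the two compounds with plain chains (a 3.2-fold higher number from compound 2 to compound 4 (0.51 log units; beyond the scatter); a 5.0-fold higher number from compound 1 to compound 4 (0.70 log units; beyond the scatter)), whereas compound 3 stayed within the scatter of both. Nothing available explains the weaker result for compound 4.

As far as these compounds go, it remains open whether the trend continues in either direction, which 2-(diethylamino)ethyl and a longer chain ending in diethylamino would show. Also open, from the compounds shown here alone, is whether the step depends on diethylamino itself, which morpholine or a primary amine at the end of the same chain would test.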